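The compounds below may be only part of what the source reports. "The series", "measured", "known", "first", "only" and "open" are said of these compounds alone.

In a functional assay on SK-MEL-28 cells (Homo sapiens) for inhibition (on this read-out lower numbers stand for stronger inhibition and higher numbers for weaker inhibition), compound 1, `Cc1ccc(/C=C/c2ccc3ccccc3c2)cc1`, gives > 5000 nM, which is a limit and not a number. Compound 2, `Cc1ccc(/C=C\c2ccc3ccccc3c2)cc1`, gives > 5000 nM, also a limit. Compound 3, `FC(F)(F)c1ccc(/C=C/c2ccc3ccccc3c2)cc1`, gives > 5000 nM, again only a limit, so its place in the series cannot be fixed more closely. All three readings rest on (the limit of > 5000 nM in this assay, at which 3 of the 3 values shown sit).

Compound 4, `FC(F)(F)c1ccc(/C=C\c2ccc3ccccc3c2)cc1`, is the partner of compound 3: the two compounds have the same atoms and bonds and differ only in configuration as drawn: 1 of 1 stereo elements differ; a double bond is drawn E in compound 3 and Z in compound 4. Going by the values given here, the nearest precedent is a step that the two limits leave unreadable from compound 1 to compound 2, the same change of double bond configuration in the methyl pair, and it rests on (the fact that compounds 1 and 2 differ only in the configuration as drawn). The exchange of groups seen in a step that the two limits leave unreadable from compound 1 to compound 3 gives no readable size either. Among the compounds with values here, neither step shows any movement, so no measured step points to a gain or a loss, and the expectation is that the new configuration leaves the result near the limit. The estimated change is a step that the limit leaves unreadable from compound 3 to compound 4. Compound 4 is expected at 5500 nM, with an estimated range from 2000 nM to 10000 nM.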

Compound 4, half-maximal inhibitory concentration: > 5000 nM
Compound 4 ended at the assay's limit; the forecaster's own chance of this, stated with the estimate: 80%; the middle value does not contradict the limit.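

Compound 4, like compound 2 and compound 3, reads only as a limit, so neither the change of double bond configuration nor the trifluoromethyl in place of methyl gives a readable step. The compounds shown leave open how strongly any of compound 1, compound 2, compound 3 and compound 4 inhibits in this assay.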